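The source may hold more compounds than are shown below. What is called first, only, known or untested is meant among the compounds shown, and "the series" means these compounds.

Among the compounds with values here, in an ADME assay on CHO cells (Cricetulus griseus) for cytotoxicity, read by LDH release (on this read-out lower numbers stand for stronger inhibition and higher numbers for weaker inhibition), only two compounds have been measured so far, and neither gives an actual number. Compound 1 `CC(Nc1ccc(Cl)cc1Cl)C(=O)NCc1ccc(F)cc1` gives > 100000 nM as its result, which is a limit of the assay. Compound 2 `CCCC(NC(=O)C(C)Oc1ccc(Cl)cc1Cl)c1ccc(F)cc1` gives > 100000 nM as its result, which is also a limit. Both results therefore sit together at the limit of > 100000 nM in this assay, at which 2 of the 2 values shown sit, and no size of step can be read from them.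

Compound 3 `CCCCC(NC(=O)C(C)Oc1ccc(Cl)cc1Cl)c1ccc(F)cc1` differs from compound 2 in one place: methyl in place of hydrogen on a saturated chain carbon, four bonds along the chain from an amide-type nitrogen and an aromatic carbon and so the propyl chain becomes butyl. The expectation rests on compound 2 with its limit of > 100000 nM and on how small this change is. The estimated step of a number no higher from compound 2 to compound 3 (the limit leaves the size open) is expected to stay within the usual scatter in this assay with no clear direction. For compound 3 the expected value is 100000 nM with an estimated range from 40000 nM to 200000 nM and another limit is likely.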

Compound 3, half-maximal inhibitory concentration: > 100000 nM
Compound 3: only a limit was reported; the forecaster's own chance of this, stated with the estimate: 85%; the middle value sits exactly at the limit.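

No step can be read from compound 2 to compound 3, because both results are limits and not numbers: the limit of > 100000 nM in this assay, at which 3 of the 3 values shown sit.

The compounds shown leave open what actual number any of them would give in this assay, and whether going from propyl to butyl changes the result at all.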